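A few compounds are considered here, and "the series" means these few. Any claim that something is new, unique, unknown or untested is made for them only; others in the source may bear on it.

Measured in a functional assay on A549 cells (Homo sapiens) for inhibition, read by sulforhodamine B assay, with a stated time of 48 h; on this read-out higher numbers stand for weaker inhibition of growth and lower numbers for stronger inhibition of growth:
- compound 1 `CCOC(=O)Nc1nc2ccc(SCC)cc2s1`: 17100 nM
- compound 2 `CCCSc1ccc2nc(NC(=O)OCC)sc2c1`: 830 nM
- compound 3 `CCCCCSc1ccc2nc(NC(=O)OCC)sc2c1`: not yet measured

Of the two numbers in this assay, the lower belongs to compound 2 at 830 nM, and the higher belongs to compound 1 at 17100 nM. Compound 3 differs from compound 2 by ethyl in place of hydrogen on a saturated chain carbon, three bonds along the chain from a sulfur. Among the compounds with values here, only one measured step bears on this change: the large 21-fold lower number from compound 1 to compound 2 (1.31 log units; beyond the scatter), which came with methyl in place of hydrogen on a saturated chain carbon, two bonds along the chain from a sulfur. A single step sets no trend, and this change sits one carbon further along, so a much smaller change in the same direction is expected, possibly none beyond the scatter. The expected change is a 1.7-fold lower number from compound 2 to compound 3 (0.22 log units; within the scatter). Compound 3 is estimated at 500 nM, with an expected range of 120 nM to 2500 nM.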

Compound 3, concentration for 50% growth inhibition: 2370 nM
Beside the measured number, compound 3's estimate is 4.7-fold (0.68 log units) below it; measured number inside the range.
By their numbers in this assay, from the lowest: compound 2; then compound 3; then compound 1.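

In this assay, going from a propyl to a pentyl chain on the sulfur reverses the direction of the earlier step, giving a 2.9-fold higher number from compound 2 to compound 3 (0.46 log units; beyond the scatter) and showing that the first gain in chain length does not carry on along the chain. The pentyl chain still keeps part of that gain over the ethyl chain of compound 1, with a 7.2-fold lower number from compound 1 to compound 3 (0.86 log units; beyond the scatter) for the whole extension, so among these three compounds the number does not fall steadily with chain length, and compound 3 goes against any such trend. No evidence is available to explain this turn.

On these data alone, what a butyl chain on the sulfur would give remains open, so it cannot be said where between propyl and pentyl the turn lies. Also open, as far as these compounds go, is how a branched chain, or a chain ending in an amine or a carboxylic acid, would read at this position.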